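This account rests on a few compounds, and the source may have more. Where it says the series, first, only, none or still open, it means among the compounds named here.

Measured so far in an ADME assay on Caco-2 cells (Homo sapiens) for permeability, in the apical to basolateral direction; on this read-out lower numbers stand for lower permeability and higher numbers for higher permeability:
- compound 1 `CC(=O)N1CCN([C@H]2CC[C@H](Nc3ncnn4ccc(C(C)C)c34)CC2)CC1`: 38 10^-6 cm/s
- compound 2 `Cc1ccn2ncnc(N[C@H]3CC[C@H](N(C)C)CC3)c12`: 36 10^-6 cm/s
- compound 3 `CN(C)[C@H]1CC[C@H](Nc2ncnn3ccc(C4CCOCC4)c23)CC1`: 14 10^-6 cm/s

Compound 3 stands lowest of the three numbers, and the other two both lie above it by more than the scatter. The next compound, compound 4 `CC(C)c1ccn2ncnc(N[C@H]3CC[C@H](N(C)C)CC3)c12`, changes one group on compound 3: isopropyl in place of oxan-4-yl on an aromatic carbon in short, isopropyl in place of oxan-4-yl on an aromatic carbon.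

Within the data shown here, the only measured step at this group is a 2.6-fold lower number from compound 2 to compound 3 (0.41 log units; beyond the scatter) with oxan-4-yl in place of methyl on an aromatic carbon. It was modest but beyond the scatter, and it points to a higher number once oxan-4-yl leaves. Compound 1 also carries isopropyl and gives 38 10^-6 cm/s as its number, but it differs from compound 4 elsewhere, so it serves only as a loose guide. Among the measured compounds shown here, no measured pair compares isopropyl directly with another group while all else stays the same.

A rise similar in size to the measured step, and beyond the scatter, is therefore expected in this assay. The expected step is a 2.4-fold higher number from compound 3 to compound 4 (0.39 log units; beyond the scatter) on this estimate. For compound 4 the estimated value is 34 10^-6 cm/s with an expected range from 18 10^-6 cm/s to 60 10^-6 cm/s as its limits.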

Compound 4, apparent permeability: 26 10^-6 cm/s
Compound 4: the middle estimate sits 1.3-fold (0.12 log units) above what was measured, within the range that was stated.
By their numbers in this assay, from the lowest: compounds 3, 4, 2 and 1 (each within the scatter of the next, the first and the last beyond it).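

At the aromatic carbon, isopropyl is not separated from either neighbouring group in this assay: replacing oxan-4-yl gives (a 1.9-fold higher number from compound 3 to compound 4 (0.27 log units; within the scatter)) and replacing methyl gives (a 1.4-fold lower number from compound 2 to compound 4 (0.14 log units; within the scatter)), so both steps stay within the scatter even though methyl and oxan-4-yl remain apart (a 2.6-fold lower number from compound 2 to compound 3 (0.41 log units; beyond the scatter)). At this position, only the methyl and oxan-4-yl pair can therefore be told apart, and isopropyl gives no ordering among the three groups. The series also gains a direct reading at the saturated ring carbon, where dimethylamino in place of 4-acetylpiperazin-1-yl gives (a 1.5-fold lower number from compound 1 to compound 4 (0.16 log units; within the scatter)), again within the scatter, and no measurement is available to explain any of these steps.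

Going by these compounds, how a carboxylic acid or a longer alkyl chain on the aromatic carbon would read in this assay remains open, as does a primary amine in place of dimethylamino on the saturated ring carbon. Also open, on these data alone, is whether changes at these two places act independently or together.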